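The source may report more compounds than this note shows. Statements on the series, on what has been measured and on what is new or still open speak of the compounds shown alone.

Going by the values given here, compound 1 `COc1ccc(-c2cc3ccccc3nc2/C=C/C(=O)c2ccccc2)cc1` gives 700 nM in a functional assay on SK-BR-3 cells (Homo sapiens) for antiproliferative activity, read by XTT assay, with a stated time of 72 h (on this read-out lower numbers stand for stronger inhibition and higher numbers for weaker inhibition), the lowest of the two numbers so far; the nearest is compound 2 `COc1ccc(-c2cc3ccccc3nc2/C=C/C(=O)c2cccs2)cc1`, which in this assay gives 800 nM. Among the compounds with values here, the single measured step, a 1.1-fold higher number from compound 1 to compound 2 (0.06 log units; within the scatter), is within the scatter, so the two values carry no order between them. Compound 3 `COc1ccc(-c2cc3ccccc3nc2/C=C/C(=O)c2ccsc2)cc1` differs from compound 1 by thiophen-3-yl in place of phenyl on a carbonyl carbon The group that enters is thiophen-3-yl, a five-membered aromatic ring with one hetero atom, on the same carbonyl carbon where compound 2 carries thiophen-2-yl. The step from compound 1 to compound 2 is the only one that bears on this change, and it was within the scatter. On that basis the step expected in this assay is a 1.1-fold higher number from compound 1 to compound 3 (0.03 log units; within the scatter), nothing beyond the scatter in either direction. Compound 3 is estimated at 750 nM, with an expected range from 350 nM to 1600 nM.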

Compound 3, half-maximal inhibitory concentration: 660 nM
Compound 3: the middle estimate sits 1.1-fold (0.06 log units) above what was measured; measured number inside the range.
By their numbers in this assay, from the lowest: compounds 3, 1 and 2 (each within the scatter of the next).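

In this assay, thiophen-3-yl in place of phenyl on the carbonyl carbon stays within the scatter (a 1.1-fold lower number from compound 1 to compound 3 (0.03 log units; within the scatter)), and so does thiophen-3-yl in place of thiophen-2-yl (a 1.2-fold lower number from compound 2 to compound 3 (0.08 log units; within the scatter)). The second comparison is new: the two thiophene attachments can now be set side by side at this position, and they show no readable difference, so compounds 1, 2 and 3 carry no order among them. No measured evidence bears on why these three groups read alike.

Open is how far this tolerance extends: all three groups are aromatic rings, so the compounds shown do not tell whether a cyclohexyl ring, a longer alkyl chain or a phenyl ring bearing an amine or a carboxylic acid on this carbonyl carbon would give a step beyond the scatter. Also open, on these data alone, is whether the shared core elsewhere is as tolerant as this position.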